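Two amines in place of an acetoxy chain on the shared core

This account rests on a few compounds, and the source may have more. Where it says the series, first, only, none or still open, it means among the compounds named here.

In an assay on HeLa cells for inhibition of sphingosine-1-phosphate transporter SPNS2 (Mus musculus), read by LC-MS, tested at 2 uM (a higher number here means more inhibition at the concentration tested (going by the name of the read-out), a lower number less inhibition), compound 1 `CCCCCCCCCCc1ccc(-c2noc(CCCN)n2)cc1` gives 67%, while compound 2 `CCCCCCCCCCc1ccc(-c2noc(CC(CN)OC(C)=O)n2)cc1` gives 0%, the lowest of the two numbers, with the step of a number 67 percentage points lower from compound 1 to compound 2 (beyond the scatter). Compound 3 `CCCCCCCCCCc1ccc(-c2noc([C@@H](N)CCN)n2)cc1` differs from compound 2 by a group of 5 heavy atoms (3 carbon, 2 nitrogen; no ring) in place of a group of 8 heavy atoms (5 carbon, 1 nitrogen, 2 oxygen; no ring), on an aromatic carbon, with 1,3-diaminopropyl entering and carrying a defined stereocentre. Going by the values given here, the only step that bears on this change is the large fall from compound 1 to compound 2 on bringing in acetoxy; that group now leaves, so a large rise in this assay is expected, a number 70 percentage points higher from compound 2 to compound 3 (beyond the scatter). For compound 3 the estimated value is 70%, in the range 40% to 95%.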

Compound 3, a percentage reported as inhibition, at one concentration (the size of the read-out at that concentration, not a potency): 14%
The estimate for compound 3 lay 56 percentage points above the measured number; measured number outside the range, below it.
By their numbers in this assay, from the lowest: compound 2; then compound 3; then compound 1.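

In this assay the exchange of the acetoxy chain for 1,3-diaminopropyl gives only a number 14 percentage points higher from compound 2 to compound 3 (beyond the scatter) and does not bring the number back to that of compound 1. Amino on the saturated chain carbon bound to an aromatic carbon and a saturated chain carbon gives a number 53 percentage points lower from compound 1 to compound 3 (beyond the scatter) and so shows that a large loss on this chain does not belong to acetoxy alone. No measurement here accounts for that loss. On these data alone, whether it follows the amino group or its defined stereocentre stays open, as does what a hydroxyl or a methyl on the same chain carbon would give.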